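One Carbon Longer on the Amide Olefin

This account rests on a few compounds, and the source may have more. Where it says the series, first, only, none or still open, it means among the compounds named here.

Compound 2 `C=CC(=O)Nc1cccc(Oc2nc(Nc3cccc(C#N)c3)nc3ccsc23)c1` gives 4340 nM in a functional assay on A549 cells (Homo sapiens) for inhibition, read by MTT assay, with a stated time of 72 h; a lower number here means a stronger inhibitor, a higher number a weaker inhibitor.
Compound 1 `C/C=C/C(=O)Nc1cccc(Oc2nc(Nc3cccc(OC)c3)nc3ccsc23)c1` gives 10500 nM in this assay.

Compound 2 holds the lower of the two numbers; compound 1 sits above it by a gap beyond the scatter. Compound 3 `C/C=C/C(=O)Nc1cccc(Oc2nc(Nc3cccc(C#N)c3)nc3ccsc23)c1` differs from compound 2 by prop-1-en-1-yl in place of vinyl on a carbonyl carbon. Among the measured compounds shown here, no measured pair isolates this change, and compound 1 differs from compound 2 in a second place as well, so its gap tells nothing about this step alone. A modest weakening, near the edge of the scatter, is expected in this assay, as a 1.6-fold higher number from compound 2 to compound 3 (0.21 log units; within the scatter). Compound 3 is therefore estimated at 7000 nM, within a range from 2500 nM to 20000 nM.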

Compound 3, half-maximal inhibitory concentration: 11300 nM
The estimate for compound 3 lay 1.6-fold (0.21 log units) below the measured number; low and high end bracket the measured number.
By their numbers in this assay, from the lowest: compound 2; then compounds 1 and 3 (each within the scatter of the next).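

In this assay the change on the carbonyl carbon can now be read alone: prop-1-en-1-yl in place of vinyl gives a 2.6-fold higher number from compound 2 to compound 3 (0.42 log units; beyond the scatter), so this position does respond to the longer olefin, and the response is a weakening. With prop-1-en-1-yl held fixed, cyano in place of methoxy on an aromatic carbon gives a 1.1-fold higher number from compound 1 to compound 3 (0.03 log units; within the scatter), which leaves compound 1 and compound 3 unseparated. Nothing at hand accounts for either step.

Going by these compounds, whether a longer chain or an amine-bearing chain in place of prop-1-en-1-yl on the carbonyl carbon would shift the number further stays open. So does whether the step from vinyl to prop-1-en-1-yl keeps its size with methoxy on the aromatic carbon.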